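The compounds below may be only part of what the source reports. "The series", "measured", "known", "first", "only" and "open" are said of these compounds alone.

In a functional assay on HUVEC cells (Homo sapiens) for antiproliferative activity, read by MTT assay, with a stated time of 24 h (on this read-out higher numbers stand for weaker inhibition and lower numbers for stronger inhibition), compound 1 `COc1cc(OC)c(-c2coc3cc(OCC=C(C)C)ccc3c2=O)cc1OC` gives 3800 nM, and compound 3 `COc1cc(OC)c(-c2coc3cc(OCc4ccc(Cl)cc4)ccc3c2=O)cc1OC` gives 4400 nM. Those two numbers lie within the scatter of each other, as a 1.2-fold higher number from compound 1 to compound 3 (0.06 log units; within the scatter) shows, so neither can be ranked ahead. Compound 2 `COc1cc(OC)c(-c2coc3cc(OCc4ccccc4C#N)ccc3c2=O)cc1OC` gives only a limit, > 10000 nM, and no number. Compound 3 stands clear of that limit, with an at least 2.2-fold lower number from compound 2 to compound 3 (0.35 log units; beyond the scatter).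

Compound 4 `COc1cc(OC)c(-c2coc3cc(OCc4cccc(Br)c4)ccc3c2=O)cc1OC` carries 3-bromophenyl in place of 4-chlorophenyl on a saturated chain carbon bound to an oxygen on an aromatic ring. Among the measured compounds shown here, the steps that bear on this change are those made at the same place. Among them, a 1.2-fold higher number from compound 1 to compound 3 (0.06 log units; within the scatter) stayed within the scatter, while the swap to 2-cyanophenyl gave an at least 2.6-fold higher number from compound 1 to compound 2 (0.42 log units; beyond the scatter). The new group resembles 4-chlorophenyl more closely than 2-cyanophenyl, so no large move is expected in this assay. The expected change is a 1.1-fold higher number from compound 3 to compound 4 (0.06 log units; within the scatter), which would stay within the scatter. For compound 4 the estimated value is 5000 nM, with an expected range from 2000 nM to 10000 nM.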

Compound 4, half-maximal inhibitory concentration: > 10000 nM
Compound 4 ended at the assay's limit; the forecaster's own chance of this, stated with the estimate: 15%; at least 2.0-fold (0.30 log units) between middle value and limit.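

In this assay, the exchange of 4-chlorophenyl for 3-bromophenyl on a saturated chain carbon bound to an oxygen on an aromatic ring is not a neutral swap, even though the two groups have the same heavy-atom count (an at least 2.2-fold higher number from compound 3 to compound 4 (0.35 log units; beyond the scatter)). Compound 1 and compound 3 lay within the scatter of each other and suggested a tolerant position, but 3-bromophenyl also separates clearly from the 2-methylprop-1-en-1-yl group of compound 1 (an at least 2.6-fold higher number from compound 1 to compound 4 (0.42 log units; beyond the scatter)). The reading for compound 4 is a limit and not a number, so both steps give only a minimum size, and the step between compound 2 and compound 4 cannot be read: the limit of > 10000 nM in this assay, at which 2 of the 4 values shown sit.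

As far as these compounds go, compound 4 changes both the halogen and its ring position at once, so it remains open which of the two matters. A 4-bromophenyl or 3-chlorophenyl group at this place would separate them.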